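The source may hold more compounds than are shown below. What is called first, only, known or untested is meant among the compounds shown, and "the series" means these compounds.

Compound 1 `CCc1nnc(O)n2c(C)nc(C)c12` and compound 2 `CCCc1nnc(O)n2c(C)nc(C)c12` share one core, while compound 3 `CCc1nc(C)c2cnnc(S)n12` is built on a second core; the difference between the two cores is not broken down here. In a functional assay for inhibition, with Homo sapiens as the target (a higher number here means a weaker inhibitor, a lower number a stronger inhibitor), compound 1 gives only a limit, > 48000 nM. Compound 2 likewise reaches only a limit in this assay, > 48000 nM. Compound 3 too stops at a limit, > 48000 nM. The change from compound 1 to compound 2 is methyl in place of hydrogen on a saturated chain carbon, two bonds along the chain from an aromatic carbon, and the step it made is a step that the two limits leave unreadable from compound 1 to compound 2, since all three values sit at the limit of > 48000 nM in this assay, at which 3 of the 3 values shown sit. Compound 4 `Cc1nc(C(C)C)n2c(S)nncc12` is not yet measured; it differs from compound 3 by methyl in place of hydrogen on a saturated chain carbon bound to an aromatic carbon and a saturated chain carbon, the same kind of change, though here the place is a saturated chain carbon bound to an aromatic carbon and a saturated chain carbon rather than one two bonds along the chain from an aromatic carbon. Because the values shown sit at the limit of > 48000 nM in this assay, at which 3 of the 3 values shown sit, compound 4 is expected to give a step that the limit leaves unreadable from compound 3 to compound 4 and is estimated at 60000 nM.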

Compound 4, half-maximal inhibitory concentration: > 48000 nM
Compound 4: a limit, no number; the forecaster's own chance of this, stated with the estimate: 85%; the middle value lies beyond the limit too.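

No size can be read for the change from compound 3 to compound 4, because both stop at a limit: the limit of > 48000 nM in this assay, at which 4 of the 4 values shown sit.

The compounds shown leave open whether any of them, on either core, reaches a measurable value in this assay, and what adding the methyl does there.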